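Methyl position on the hydroxyphenyl imine

The source may report more compounds than this note shows. Statements on the series, on what has been measured and on what is new or still open speak of the compounds shown alone.

Measured so far:
compound 1 `Cc1cccc(/C=N/c2ccc(OCc3ccccc3)cc2)c1O`: 15500 nM
compound 2 `Oc1ccc(/C=N/c2ccc(OCc3ccccc3)cc2)c(O)c1`: 6780 nM
compound 3 `Oc1cccc(/C=N/c2ccc(OCc3ccccc3)cc2)c1O`: 6870 nM

In an assay on isolated protein for inhibition of Amine oxidase [flavin-containing] B (Homo sapiens), read by fluorescence and Amplex Red, with stated times of 15 min and 20 min (a lower number here means a stronger inhibitor, a higher number a weaker inhibitor), compound 1 gives the highest number of the three; compound 3 and compound 2 both sit lower, by the steps of a 2.3-fold lower number from compound 1 to compound 3 (0.35 log units; beyond the scatter) and a 2.3-fold lower number from compound 1 to compound 2 (0.36 log units; beyond the scatter). Compound 4 `Cc1ccc(/C=N/c2ccc(OCc3ccccc3)cc2)c(O)c1` is not yet measured; it differs from compound 1 by 2-hydroxy-4-methylphenyl in place of 2-hydroxy-3-methylphenyl on a carbon with a double bond to nitrogen. For the measured compounds named here, no measured step moves a methyl on this ring. The nearest guide is the shift of a hydroxy between the same two places, a 1.0-fold higher number from compound 2 to compound 3 (0.01 log units; within the scatter), which stayed within the scatter. The two steps that did lower the number, a 2.3-fold lower number from compound 1 to compound 3 (0.35 log units; beyond the scatter) and a 2.3-fold lower number from compound 1 to compound 2 (0.36 log units; beyond the scatter), each introduced a further hydroxy rather than relocating a group. A step of no more than the scatter is therefore expected, a 1.2-fold lower number from compound 1 to compound 4 (0.08 log units; within the scatter). Compound 4 is estimated at 13000 nM, between 6000 nM and 30000 nM.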

Compound 4, half-maximal inhibitory concentration: 24400 nM
Estimate against measurement, compound 4: 1.9-fold (0.27 log units) below; the measured number falls inside the stated range.
By their numbers in this assay, from the lowest: compounds 2 and 3 (each within the scatter of the next); then compounds 1 and 4 (each within the scatter of the next).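

Moving the methyl, from 2-hydroxy-3-methylphenyl to 2-hydroxy-4-methylphenyl, gives a 1.6-fold higher number from compound 1 to compound 4 (0.20 log units; within the scatter), so the two placements of the methyl are not told apart. Methyl in place of hydroxy gives a 3.6-fold higher number from compound 2 to compound 4 (0.56 log units; beyond the scatter), and 2-hydroxy-4-methylphenyl in place of 2,3-dihydroxyphenyl gives a 3.6-fold higher number from compound 3 to compound 4 (0.55 log units; beyond the scatter). The exchange of methyl for hydroxy therefore now reads on two cores, with steps of similar size: the same change on two cores in this assay, a 2.3-fold lower number (0.35 log units; beyond the scatter) from compound 1 to compound 3 and a 3.6-fold lower number (0.56 log units; beyond the scatter) from compound 4 to compound 2, 1.6-fold (0.20 log units) apart, within the scatter of two such steps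

Open, from the compounds shown here alone, is whether the lower numbers belong to hydroxy itself. A methoxy or an amine at the same places on the ring would test this.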